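The source may report more compounds than this note shows. Statements on the series, on what has been measured and on what is new or still open speak of the compounds shown alone.

In a functional assay on C8166 cells (Homo sapiens) for cytotoxicity, read by MTT assay (a higher number here means that more compound is tolerated, a lower number that less compound is tolerated), compound 1 (`Cc1cc(S(N)(=O)=O)ccc1NC(=O)COc1ccc(Cl)cc1NC(=O)c1ccccc1[N+](=O)[O-]`) gives 54800 nM and compound 2 (`COc1ccc(C(=O)Nc2cc(Cl)ccc2OCC(=O)Nc2ccc(S(N)(=O)=O)cc2C)cc1`) gives 69500 nM. For the measured compounds named here, compound 2 therefore stands level with compound 1 within the scatter, and these are the only two numbers available so far. Compound 3 (`Cc1ccc(C)c(C(=O)Nc2cc(Cl)ccc2OCC(=O)Nc2ccc(S(N)(=O)=O)cc2C)c1`) has not yet been measured. It keeps the shared core of compound 2 and carries 2,5-dimethylphenyl in place of 4-methoxyphenyl on a carbonyl carbon. Going by the values given here, the one measured step that bears on this change was made at the same place, and at a 1.3-fold higher number from compound 1 to compound 2 (0.10 log units; within the scatter) it stays within the scatter. A step beyond the scatter is therefore not expected for compound 3 in this assay, although a single step is thin evidence. The expected step is a 1.2-fold lower number from compound 2 to compound 3 (0.06 log units; within the scatter). Compound 3 is estimated at 60000 nM, with an expected range from 25000 nM to 140000 nM.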

Compound 3, half-maximal cytotoxic concentration: 79700 nM
Estimate against measurement, compound 3: 1.3-fold (0.12 log units) below; the measured number falls inside the stated range.
By their numbers in this assay, from the lowest: compounds 1, 2 and 3 (each within the scatter of the next).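

In this assay, the exchange of 4-methoxyphenyl for 2,5-dimethylphenyl on the carbonyl carbon, which leaves no hydrogen-bond acceptor in the group, gives a 1.1-fold higher number from compound 2 to compound 3 (0.06 log units; within the scatter), and the exchange of 2-nitrophenyl for the same group gives a 1.5-fold higher number from compound 1 to compound 3 (0.16 log units; within the scatter). Neither step lies beyond the scatter, so across these three compounds a phenyl ring bearing only methyl groups reads level with those bearing methoxy or nitro at this position. Nothing measured alongside these numbers offers an explanation for this.

The compounds shown leave open whether steps at this position stay within the scatter when the phenyl ring carries an amine or a carboxylic acid, or gives way to a cyclohexyl ring. They also leave open whether replacing the chlorine on the shared core would produce a step beyond the scatter.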